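This account rests on a few compounds, and the source may have more. Where it says the series, first, only, none or still open, it means among the compounds named here.

Measured compounds:
- compound 1, `O=C(O)c1cccc(Cc2c(-c3ccc(Cl)cc3)nn3cc(Cl)ccc23)n1` — 1100 nM
- compound 2, `COc1ccc(-c2nn3cc(Cl)ccc3c2Cc2cccc(C(=O)O)n2)cc1` — 5400 nM
- compound 3, `O=C(O)c1cccc(Cc2c(-c3ccco3)nn3cc(Cl)ccc23)n1` — 1200 nM

In a functional assay on cells for antagonist activity at prostaglandin E2 receptor EP1 subtype (Rattus norvegicus), read by fluorescence and calcium flux, with a stated time of 60 s (on this read-out lower numbers stand for stronger inhibition and higher numbers for weaker inhibition), compound 3 gives the second highest of the three numbers. Its nearest neighbour is compound 1: the step of a 1.1-fold higher number from compound 1 to compound 3 (0.04 log units; within the scatter) lies within the scatter, so the two cannot be ranked. The furthest is compound 2, and the step of a 4.5-fold lower number from compound 2 to compound 3 (0.65 log units; beyond the scatter) is beyond the scatter. The only other shown step at this place, a 4.9-fold higher number from compound 1 to compound 2 (0.69 log units; beyond the scatter), is of similar size.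

Compound 4, `O=C(O)c1cccc(Cc2c(-c3ccoc3)nn3cc(Cl)ccc23)n1`, differs from compound 3 only at the group attached to the shared core: furan-3-yl in place of furan-2-yl on an aromatic carbon. Among the compounds with values here, no measured step changes the point of attachment of a group at this position; the steps that bear on it are those that swap one aryl for another there. Of these, a 1.1-fold higher number from compound 1 to compound 3 (0.04 log units; within the scatter) was within the scatter, while a 4.9-fold higher number from compound 1 to compound 2 (0.69 log units; beyond the scatter) and a 4.5-fold lower number from compound 2 to compound 3 (0.65 log units; beyond the scatter) were modest. A change that keeps the same atoms and only moves the attachment is therefore expected to produce at most a small step in this assay, in no clear direction, and quite possibly none beyond the scatter.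

Compound 4 is expected to give about 1500 nM, with a likely range from 600 nM to 4000 nM. This corresponds to an expected 1.3-fold higher number from compound 3 to compound 4 (0.10 log units; within the scatter).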

Compound 4, half-maximal inhibitory concentration: 130 nM
The estimate for compound 4 lay 12-fold (1.06 log units) above the measured number; the whole stated range lies above it.
By their numbers in this assay, from the lowest: compound 4; then compounds 1 and 3 (each within the scatter of the next); then compound 2.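

In this assay, moving only the point of attachment of the furan ring gives a 9.2-fold lower number from compound 3 to compound 4 (0.97 log units; beyond the scatter) even though furan-2-yl and furan-3-yl have the same atoms and the same counts of hydrogen-bond donors and acceptors, so this position responds to how the ring is joined and not only to which ring sits there. Furan-3-yl also stands apart from both phenyl groups, with an 8.5-fold lower number from compound 1 to compound 4 (0.93 log units; beyond the scatter) and with the large 42-fold lower number from compound 2 to compound 4 (1.62 log units; beyond the scatter) as well, whereas furan-2-yl and 4-chlorophenyl could not be ranked against each other, so the earlier swaps gave no hint of a number this low at this place. Nothing in the data shown explains why the point of attachment matters so much.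

The compounds shown leave open whether the same difference appears with other rings joined in the two ways, such as thiophen-2-yl against thiophen-3-yl, and whether a methyl group on furan-3-yl keeps the low number. They also leave open whether furan-3-yl gives a similar step when the carboxylic acid of the shared core is replaced by a tetrazole or an amide.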